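Replacing the Aromatic End Group of Compound 1

The compounds below may be only part of what the source reports. "The series", "measured", "known", "first", "only" and "open" are said of these compounds alone.

Compound 1 `C=C/C=C\[C@H](C)[C@H](OC(N)=O)[C@@H](C)[C@H](O)[C@@H](C)C/C(C)=C\[C@H](C)[C@@H](O)[C@@H](C)/C=C\CCc1cccc(O)c1C` is assessed in a functional assay on MCF7 cells (Homo sapiens) for cytotoxicity (on this read-out higher numbers stand for weaker inhibition and lower numbers for stronger inhibition), where compound 1 gives 1000 nM. Among the two numbers available it stands highest; its nearest neighbour is compound 2 `C=C/C=C\[C@H](C)[C@H](OC(N)=O)[C@@H](C)[C@H](O)[C@@H](C)C/C(C)=C\[C@H](C)[C@@H](O)[C@@H](C)/C=C\CCc1cccc(Cl)c1`, which in this assay gives 650 nM, and the step of a 1.5-fold lower number from compound 1 to compound 2 (0.19 log units; within the scatter) lies within the scatter. Compound 3 `C=C/C=C\[C@H](C)[C@H](OC(N)=O)[C@@H](C)[C@H](O)[C@@H](C)C/C(C)=C\[C@H](C)[C@@H](O)[C@@H](C)/C=C\CCc1ccsc1` has not yet been measured. It differs from compound 1 in that (thiophen-3-yl in place of 3-hydroxy-2-methylphenyl on a saturated chain carbon, two bonds along the chain from a double-bonded chain carbon). Going by the values given here, the only measured step that bears on this change is the one from compound 1 to compound 2, which also exchanged the 3-hydroxy-2-methylphenyl group at the same place and stayed within the scatter. Among the compounds with values here, with only that single exchange to go on, the move to thiophen-3-yl is expected to give no step beyond the scatter, so a 1.2-fold higher number from compound 1 to compound 3 (0.08 log units; within the scatter) is the expected change. Compound 3 is therefore estimated at 1200 nM in this assay, with a range from 400 nM to 3600 nM.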

Compound 3, half-maximal inhibitory concentration: 4000 nM
For compound 3 the middle estimate is 3.3-fold (0.52 log units) below the measured one; measured number outside the range, above it.
By their numbers in this assay, from the lowest: compounds 2 and 1 (each within the scatter of the next); then compound 3.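

In this assay this position now shows a step beyond the scatter, with a 4.0-fold higher number from compound 1 to compound 3 (0.60 log units; beyond the scatter) and with a 6.2-fold higher number from compound 2 to compound 3 (0.79 log units; beyond the scatter), so the end group on this chain is not freely exchangeable, as the earlier pair alone might have suggested. Compound 1 and compound 2 both carry a six-membered aromatic ring of carbon only, whereas compound 3 carries thiophen-3-yl, a five-membered aromatic ring with a sulfur atom and no further substituent. Nothing at hand accounts for this rise.

These compounds cannot separate the ring size, the sulfur atom and the missing ring substituents from one another. On these data alone, whether an unsubstituted phenyl, a 3-chlorothiophene or a furan-3-yl ring would stay with compound 1 and compound 2 or move with compound 3 remains open.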